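Amide nitrogen substituent in a furan-linked pyrazole series

The compounds below may be only part of what the source reports. "The series", "measured", "known", "first", "only" and "open" are said of these compounds alone.

The series shares one core carrying a carboxamide. Compound 1 `Cc1cc(C(N)=O)nn1Cc1cc(Cl)cc2cc(-c3ccccc3)oc12` is the primary amide; in an assay on CHO-K1 cells for displacement of a labelled ligand from prostaglandin E2 receptor EP1 subtype (Homo sapiens), read by scintillation counting, with a stated time of 45 min (a higher number here means a weaker inhibitor, a lower number a stronger inhibitor), compound 1 gives 5.01 nM. Compound 2 `Cc1cc(C(=O)NC(C)(C)C)nn1Cc1cc(Cl)cc2cc(-c3ccccc3)oc12` carries tert-butyl on the amide nitrogen, and in this assay compound 2 gives 10 nM. The only measured step, a 2.0-fold higher number from compound 1 to compound 2 (0.30 log units; within the scatter), places compound 2 and compound 1 within the scatter of each other, so on the numbers shown compound 2 is not separated from compound 1.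

Compound 3 `Cc1cc(C(=O)NC2CC2)nn1Cc1cc(Cl)cc2cc(-c3ccccc3)oc12` differs from compound 2 by cyclopropyl in place of tert-butyl on an amide-type nitrogen. Going by the values given here, the step that bears on this is the one from compound 1 to compound 2, where going from hydrogen to tert-butyl on the same nitrogen gave a 2.0-fold higher number from compound 1 to compound 2 (0.30 log units; within the scatter). Since that step stayed within the scatter, the exchange of tert-butyl for cyclopropyl at the same position is expected to move this assay by no more than the scatter, in no fixed direction, an expected step of a 1.4-fold lower number from compound 2 to compound 3 (0.15 log units; within the scatter). Compound 3 is therefore estimated at 7 nM in this assay, with an expected range of 2.5 nM to 20 nM.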

Compound 3, half-maximal inhibitory concentration: 5.01 nM
The estimate for compound 3 lay 1.4-fold (0.15 log units) above the measured number, within the range that was stated.
By their numbers in this assay, from the lowest: compounds 1, 3 and 2 (each within the scatter of the next).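

Working notes: with cyclopropyl on the amide-type nitrogen, the series shows no change at the digits printed from compound 1 to compound 3 (within the scatter) in this assay and so gives a second substituent at this position that is not separated from the primary amide. Exchanging tert-butyl for cyclopropyl gives a 2.0-fold lower number from compound 2 to compound 3 (0.30 log units; within the scatter) and leaves the two substituted amides unseparated, although one group is an open branched group and the other holds a three-membered ring, so hydrogen, tert-butyl and cyclopropyl at this position all stand within the scatter of one another in this assay on these three compounds. No supporting measurement bears on this result.

Still open, as far as these compounds go, is whether this position stays as undiscriminating with a group of another kind on the same nitrogen, such as a carboxylic acid or a primary amine at the end of a longer chain, or a phenyl ring. Also open, from the compounds shown here alone, is whether a second substituent on that nitrogen, such as a methyl group in place of the amide hydrogen of compound 3, would stay within the scatter.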